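Bromine for methoxy on the benzyl ring of compound 1

This account rests on a few compounds, and the source may have more. Where it says the series, first, only, none or still open, it means among the compounds named here.

Measured so far in an assay on isolated protein for inhibition of Dopamine beta-hydroxylase (Rattus norvegicus); on this read-out lower numbers stand for stronger inhibition and higher numbers for weaker inhibition:
compound 1 `COc1ccc(Cn2cc[nH]c2=S)cc1`: 204000 nM
compound 2 `COc1ccc(Cn2cc[nH]c2=S)cc1OC`: 339000 nM
compound 3 `COc1ccc(Cn2cc[nH]c2=S)cc1Br`: 83200 nM

Compound 1 and compound 2 give numbers that lie within the scatter of each other, as the step of a 1.7-fold higher number from compound 1 to compound 2 (0.22 log units; within the scatter) shows, so nothing separates them. Compound 3 stands apart: the step of a 2.5-fold lower number from compound 1 to compound 3 (0.39 log units; beyond the scatter) is a modest but real drop, and the step of a 4.1-fold lower number from compound 2 to compound 3 (0.61 log units; beyond the scatter) is a somewhat larger one. Among the compounds with values here, compound 1 therefore sits with compound 2 at the weak end of the three, with compound 3 as the only compound giving a clearly lower number.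

Compound 4 `S=c1[nH]ccn1Cc1ccc(Br)cc1` differs from compound 1 by bromo in place of methoxy on an aromatic carbon. The same kind of swap, a bromo for a methoxy on an aromatic carbon, is what turns compound 2 into compound 3, and adding a bromo is what turns compound 1 into compound 3; both moved the number down beyond the scatter. A modest drop in this assay is therefore expected for compound 4, roughly a 2.9-fold lower number from compound 1 to compound 4 (0.46 log units; beyond the scatter). Compound 4 is thus estimated at 70000 nM, with a likely range from 25000 nM to 200000 nM.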

Compound 4, half-maximal inhibitory concentration: 115000 nM
Estimate against measurement, compound 4: 1.6-fold (0.22 log units) below; low and high end bracket the measured number.
By their numbers in this assay, from the lowest: compounds 3, 4, 1 and 2 (each within the scatter of the next, the first and the last beyond it).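

At the ring position para to a group of 7 heavy atoms, bromo in place of methoxy gives in this assay a 1.8-fold lower number from compound 1 to compound 4 (0.25 log units; within the scatter), so this swap alone does not clearly separate the two compounds. Within the data shown here, until now the swap had been seen only on a ring that keeps a second methoxy, where its step lay beyond the scatter. Side by side, the two steps do not differ by more than the scatter allows, so the swap may act alike on both cores, even though only one step clears the scatter by itself: the same change on two cores in this assay, a 4.1-fold lower number (0.61 log units; beyond the scatter) from compound 2 to compound 3 and a 1.8-fold lower number (0.25 log units; within the scatter) from compound 1 to compound 4, 2.3-fold (0.36 log units) apart, within the scatter of two such steps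

Going by these compounds, what a hydroxyl, an amine or a carboxylic acid would give at this position stays open. So does whether any group here can bring the number far below those of compound 3 and compound 4.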